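Swapping the pyridine partner on the amide nitrogen

The source may report more compounds than this note shows. Statements on the series, on what has been measured and on what is new or still open speak of the compounds shown alone.

Measured compounds:
- compound 1, `Cc1ccc(OCC(=O)N(Cc2cccs2)c2cccnc2)cc1`: 198 nM
- compound 2, `CCN(Cc1ccoc1)C(=O)COc1ccc(C)cc1`: 136 nM
- compound 3, `CCCc1ccc(OCC(=O)N(CC)Cc2cccs2)cc1`: 1810 nM

All three were tested in an assay on HEK293 cells for agonist activity at transient receptor potential cation channel subfamily M member 8 (Homo sapiens), read by fluorescence and calcium flux, with a stated time of 15 min; a lower number here means that less compound is needed, a higher number that more compound is needed for the effect. Among the three numbers compound 1 stands second highest. Its nearest neighbour is compound 2, whose number lies within the usual scatter of compound 1, so the two cannot be told apart. Compound 3 lies furthest away, with a number clearly beyond the scatter and higher, meaning more of compound 3 is needed than of compound 1.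

The unmeasured compound 4, `Cc1ccc(OCC(=O)N(Cc2cccs2)c2nccn2C)cc1`, keeps the whole of compound 1 except for one group on the amide-type nitrogen:

1-methyl-1H-imidazol-2-yl in place of pyridin-3-yl on an amide-type nitrogen

Among the measured compounds shown here, no measured pair in this set shows this kind of exchange, so there is nothing to lean on beyond the size of the change itself. A small shift is expected, most likely towards a somewhat higher number, but one that may well stay within the scatter; the expected step is a 1.5-fold higher number from compound 1 to compound 4 (0.18 log units; within the scatter). Compound 4 is therefore estimated at 300 nM, with a range from 100 nM to 1200 nM.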

Compound 4, half-maximal effective concentration: 1790 nM
For compound 4 the middle estimate is 6.0-fold (0.78 log units) below the measured one; measured number above the stated range.
By their numbers in this assay, from the lowest: compounds 2 and 1 (each within the scatter of the next); then compounds 4 and 3 (each within the scatter of the next).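

In this assay the exchange of pyridin-3-yl for 1-methyl-1H-imidazol-2-yl on the amide-type nitrogen gives a 9.0-fold higher number from compound 1 to compound 4 (0.96 log units; beyond the scatter) and so shows that this position is sensitive to which aromatic ring it carries. The step is large even though both groups have the same heavy-atom count and no net charge; what differs is a five-membered ring with two hetero atoms in place of a six-membered ring with one, plus one more hydrogen-bond acceptor. Nothing measured here explains why the number rises.

Open, going by these compounds, is which part of the exchange matters: the ring size, the second ring nitrogen or the methyl group. A plain phenyl ring or an imidazol-2-yl group without the methyl at this position would help to separate these.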